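Replacing the bromoindole carbonyl substituent in compound 2

A few compounds are considered here, and "the series" means these few. Any claim that something is new, unique, unknown or untested is made for them only; others in the source may bear on it.

Compound 1 `COc1ccc(/C(Cl)=C/C=C(\C#N)C(=O)c2c[nH]c3ccc(Br)cc23)cc1` gives 62.2% in a functional assay for inhibition, with a stated time of 5 min, tested at 1 mM; on this read-out higher numbers stand for more inhibition at the one concentration tested (going by the name of the read-out) and lower numbers for less inhibition.
Compound 2 `COc1cc(/C(Cl)=C/C=C(\C#N)C(=O)c2c[nH]c3ccc(Br)cc23)cc(OC)c1OC` gives 50%.
Compound 3 `COc1ccc(/C(Cl)=C/C=C(\C#N)C(=O)c2c[nH]c3ccc(Br)cc23)cc1OC` gives 80.9%.

Among these three, compound 2 stands lowest in this assay. Compound 1 lies above it, and compound 3 lies higher still, the gap being a number 30.9 percentage points higher from compound 2 to compound 3 (beyond the scatter). The other measured step, a number 18.7 percentage points higher from compound 1 to compound 3 (beyond the scatter), also concerns a methoxy group on an aromatic carbon.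

Compound 4 `COc1cc(/C(Cl)=C/C=C(\C#N)C(=O)c2c(C)[nH]c3ccccc23)cc(OC)c1OC` differs from compound 2 in one place: 2-methyl-1H-indol-3-yl in place of 5-bromo-1H-indol-3-yl on a carbonyl carbon. This is a different kind of change from the two measured steps, which both alter a methoxy group on an aromatic carbon of the shared core, whereas here one indolyl group replaces another on the carbonyl carbon. For the measured compounds named here, no measured step therefore bears on it, and the data give no direction for the change. The expectation rests on the value of compound 2 alone, with a wide range to reflect that nothing in the measured steps informs it. Compound 4 is estimated to give 45% in this assay, between 15% and 75%. That estimate means an expected step of a number 5 percentage points lower from compound 2 to compound 4 (within the scatter), not beyond the scatter.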

Compound 4, a percentage reported as inhibition, at one concentration (the size of the read-out at that concentration, not a potency): 58.2%
For compound 4 the middle estimate is 13.2 percentage points below the measured one, and the stated range covers the measured number.
By their numbers in this assay, from the lowest: compounds 2, 4 and 1 (each within the scatter of the next, the first and the last beyond it); then compound 3.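

In this assay putting 2-methyl-1H-indol-3-yl in place of 5-bromo-1H-indol-3-yl on the carbonyl carbon gives a number 8.2 percentage points higher from compound 2 to compound 4 (within the scatter) and so shows the first measured change away from the methoxy groups. For the compounds shown here, both groups have 10 heavy atoms, the same two aromatic rings and 1 hydrogen-bond donor, and the swap of bromine for an extra carbon within that frame leaves the read-out within the usual scatter at the one concentration tested, so on this evidence the carbonyl position accepts either indolyl group, whereas the methoxy changes among the earlier compounds gave steps beyond the scatter. Nothing measured here offers an explanation for this result.

From the compounds shown here alone, the step combines the loss of the bromine with the gain of the methyl, so what each contributes alone, and whether the two effects cancel, stays open. Also open, going by these compounds, is how 2-methyl-1H-indol-3-yl would read on the core of compound 3, which gives 80.9%, and what a different kind of group on the carbonyl carbon, such as an amine or a plain phenyl ring, would give.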